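From chloro to a silicon-bearing group on a shared core

The compounds below may be only part of what the source reports. "The series", "measured", "known", "first", "only" and "open" are said of these compounds alone.

Of the compounds shown here, two sharing one core have been measured so far. In a functional assay on MCF7 cells (Homo sapiens) for antiproliferative activity, read by MTT assay, with a stated time of 48 h (a higher number here means a weaker inhibitor, a lower number a stronger inhibitor), compound 1 `CC(=O)O[C@]1(C)/C=C/C(=O)/C(CO)=C\C[C@](C)(CCC=C(C)C)/C=C/[C@H]1OC(=O)C=C(C)C` gives 2320 nM as its half-maximal inhibitory concentration. In this assay compound 2 `CC(C)=CCC[C@]1(C)/C=C/[C@@H](OC(=O)C=C(C)C)[C@](C)(O)/C=C/C(=O)/C(CCl)=C\C1` gives 610 nM and so holds the lower of the two numbers, by a gap beyond the usual scatter. These two compounds differ in more than one place, so their gap isolates no single change. Compound 3 `CC(C)=CCC[C@]1(C)/C=C/[C@@H](OC(=O)C=C(C)C)[C@](C)(O)/C=C/C(=O)/C(C[Si](C)(C)C(C)(C)C)=C\C1` has yet to be measured in this assay and departs from compound 2 by one change: a group of 7 heavy atoms (6 carbon, 1 silicon; no ring) in place of one chlorine atom, on a saturated chain carbon bound to a double-bonded ring carbon in that single place.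

Among the compounds with values here, no measured pair shows what this swap does, so any forecast is loose. Within the data shown here, compound 2 at 610 nM stands at the low end of only two values, and compound 1, which carries no chlorine, stands at 2320 nM on the higher side. A move towards a higher number, meaning a weaker inhibitor, is therefore expected. The estimated change is a 2.5-fold higher number from compound 2 to compound 3 (0.39 log units; beyond the scatter) and is expected to lie a little beyond the scatter. For compound 3 the estimated value is 1500 nM within an expected range of 450 nM to 6000 nM in all.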

Compound 3, half-maximal inhibitory concentration: 6040 nM
The estimate for compound 3 lay 4.0-fold (0.60 log units) below the measured number, outside the stated range (above it).
By their numbers in this assay, from the lowest: compound 2; then compound 1; then compound 3.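

Within the data shown here, the swap at this position now has a measured size for the first time. In this assay the group of 7 heavy atoms (6 carbon, 1 silicon; no ring), placed where chloro stood on a saturated chain carbon bound to a double-bonded ring carbon, gives a 9.9-fold higher number from compound 2 to compound 3 (1.00 log units; beyond the scatter) and so marks a weaker inhibitor, which shows that the group held in this place matters to the antiproliferative read-out on the shared core. Nothing available bears on why the number rises with this change.

On these data alone, a single step cannot separate the silicon atom from the sheer count of heavy atoms in the entering group, so it remains open whether an all-carbon group such as tert-butyl, a shorter one such as methyl, or a longer chain in this same place would follow compound 3 or stay closer to compound 2. As far as these compounds go, how an amine, a fluorine atom or a carboxylic acid would behave on this saturated chain carbon also remains open, as does whether the step would keep its size with other changes elsewhere on the core.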